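Notes on one change to a shared core: sulfamoyl to cyano

A few compounds are considered here, and "the series" means these few. Any claim that something is new, unique, unknown or untested is made for them only; others in the source may bear on it.

Measured so far:
- Compound 1 `NS(=O)(=O)c1ccc(-c2nc(C(c3ccc(F)cc3)c3ccc(F)cc3)sc2CC(=O)O)cc1`: in an in vitro functional assay on HEK285-7 cells for antagonist activity at prostaglandin D2 receptor 2 (Homo sapiens), read by BRET and beta-arrestin recruitment (a higher number here means a larger maximal response, a lower number a smaller maximal response), compound 1 gives 80%.
- Compound 2 `CCC(c1ccccc1)c1nc(-c2ccc(Cl)cc2)c(CC(=O)O)s1`: in this assay compound 2 gives 50%.

Compound 1 stands highest of the two numbers in hand. Among the compounds with values here, the nearest, compound 2, lies lower by a gap that is beyond the usual scatter, but the two structures differ in several places at once, so no step from a single change between measured compounds is available, and the two values can only be taken as they are.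

Compound 3 `N#Cc1ccc(-c2nc(C(c3ccc(F)cc3)c3ccc(F)cc3)sc2CC(=O)O)cc1` is not yet measured. It differs from compound 1 in one place: cyano in place of sulfamoyl on an aromatic carbon. The rest of the structure, the shared core with its two fluorophenyl groups and the acetic acid chain, is unchanged.

Within the data shown here, with no measured single-change step to lean on, the expectation in this assay rests on compound 1 alone. The step is expected to be small, either none beyond the scatter or a modest move downward; a larger drop is possible but less likely.

The estimate for compound 3 is 70%, with a range from 45% to 95%. That estimate corresponds to an expected step of a number 10 percentage points lower from compound 1 to compound 3 (within the scatter).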

Compound 3, largest response reached (reported as efficacy), in percent of the reference or control that the assay uses: 30%
Compound 3: the middle estimate sits 40 percentage points above what was measured; the whole stated range lies above it.
By their numbers in this assay, from the lowest: compound 3; then compound 2; then compound 1.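

In this assay, the change from 4-sulfamoylphenyl to 4-cyanophenyl gives a number 50 percentage points lower from compound 1 to compound 3 (beyond the scatter), with the rest of the structure unchanged. Within the data shown here, this is the first step that can be tied to one place, and it shows that the maximal response depends strongly on the group held on this aromatic carbon, para to a large group. The change removes the hydrogen-bond donor of sulfamoyl and also alters the heavy atoms and bond types at this place, but no measurement here separates these differences or explains the size of the step.

Going by these compounds, whether methylsulfonyl or a carboxamide at this place would give a response closer to that of compound 1 or to that of compound 3 remains open, so a single step cannot show which part of the sulfamoyl group matters. Also open, on these data alone, is whether the same change would produce a step of similar size on a core without the two fluorophenyl groups.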